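Substituent next to the ring nitrogen: compounds 3 and 4

A few compounds are considered here, and "the series" means these few. Any claim that something is new, unique, unknown or untested is made for them only; others in the source may bear on it.

Measured so far:
compound 1 `CC1CCN(c2nc(C(F)(F)F)ccc2CNC(=O)Nc2cccc3c(=O)[nH]ccc23)CC1`, 9.59 nM
compound 2 `O=C(NCc1ccc(C(F)(F)F)nc1N1CCCC1)Nc1cccc2c(=O)[nH]ccc12`, 258 nM
compound 3 `CC(C)COc1nc(C(F)(F)F)ccc1CNC(=O)Nc1cccc2c(=O)[nH]ccc12`, 78.7 nM

All three values come from an assay on CHO cells for agonist activity at transient receptor potential cation channel subfamily V member 1 (Homo sapiens); a lower number here means that less compound is needed, a higher number that more compound is needed for the effect. Compound 3 stands second highest of the three numbers, bounded by the step of a 3.3-fold lower number from compound 2 to compound 3 (0.52 log units; beyond the scatter) on one side and by an 8.2-fold higher number from compound 1 to compound 3 (0.91 log units; beyond the scatter) on the other. Compound 4 `O=C(NCc1ccc(C(F)(F)F)nc1SC1CCCCC1)Nc1cccc2c(=O)[nH]ccc12` differs from compound 3 by cyclohexylsulfanyl in place of isobutoxy on an aromatic carbon. Within the data shown here, no measured step covers this exact exchange. The nearest bearings are an 8.2-fold higher number from compound 1 to compound 3 (0.91 log units; beyond the scatter), where 4-methylpiperidin-1-yl gave the lower number than isobutoxy, and a 27-fold higher number from compound 1 to compound 2 (1.43 log units; beyond the scatter), where pyrrolidin-1-yl gave the higher one. A six-membered non-aromatic ring entering here is therefore expected to move the number modestly down, as a 2.6-fold lower number from compound 3 to compound 4 (0.42 log units; beyond the scatter). Compound 4 is estimated at 30 nM, with range 8 nM to 120 nM.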

Compound 4, half-maximal effective concentration: 69.3 nM
Beside the measured number, compound 4's estimate is 2.3-fold (0.36 log units) below it; the measured number falls inside the stated range.
By their numbers in this assay, from the lowest: compound 1; then compounds 4 and 3 (each within the scatter of the next); then compound 2.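

In this assay, the exchange of isobutoxy for cyclohexylsulfanyl leaves no readable difference (a 1.1-fold lower number from compound 3 to compound 4 (0.06 log units; within the scatter)), so the six-membered non-aromatic ring of carbon only does not by itself reach the number of compound 1 (a 7.2-fold higher number from compound 1 to compound 4 (0.86 log units; beyond the scatter)). Cyclohexylsulfanyl still gives a lower number than pyrrolidin-1-yl (a 3.7-fold lower number from compound 2 to compound 4 (0.57 log units; beyond the scatter)), so the two rings do not read alike at this position. No measurement shown explains these differences. Open, going by these compounds, is whether plain piperidin-1-yl or morpholin-4-yl would stay near compound 1, and whether cyclohexyloxy would match compound 4.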